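The source may report more compounds than this note shows. Statements on the series, on what has been measured and on what is new or still open speak of the compounds shown alone.

Measured compounds:
- Compound 1 `CS/C(=N\C(=O)c1sccc1Cl)NC(=O)c1sccc1Cl`; in a functional assay on HT-29 cells (Homo sapiens) for cytotoxicity, read by MTT assay, with a stated time of 72 h (on this read-out higher numbers stand for weaker inhibition of growth and lower numbers for stronger inhibition of growth), compound 1 gives 35600 nM.
- Compound 2 `CS/C(=N\C(=O)c1cc(-c2ccccc2)nc2ccccc12)NC(=O)c1cc(-c2ccccc2)nc2ccccc12`; in this assay compound 2 gives 23700 nM.
- Compound 3 `C[Se]/C(=N\C(=O)c1cc(-c2ccccc2)nc2ccccc12)NC(=O)c1cc(-c2ccccc2)nc2ccccc12`; in this assay compound 3 gives 460 nM.

Compounds 1 and 2 carry different cores; the difference between the two cores is not broken down here. Their values in this assay lie within the usual scatter of each other, so nothing is said about their order.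

Within the core of compound 2, one change is measured: a group of 2 heavy atoms (1 carbon, 1 selenium; no ring) in place of a group of 2 heavy atoms (1 carbon, 1 sulfur; no ring), on a carbon with a double bond to nitrogen. This change gives a 52-fold lower number from compound 2 to compound 3 (1.71 log units; beyond the scatter), a step well beyond the scatter and the only one of its kind measured so far.

Compound 4 `C[Se]/C(=N\C(=O)c1sccc1Cl)NC(=O)c1sccc1Cl` is not yet measured. It differs from compound 1 in the same way: a group of 2 heavy atoms (1 carbon, 1 selenium; no ring) in place of a group of 2 heavy atoms (1 carbon, 1 sulfur; no ring), on a carbon with a double bond to nitrogen. The place of the change is worded identically in both pairs, so the change from compound 1 to compound 4 is the same change as that from compound 2 to compound 3, transferred onto the core of compound 1.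

The expectation for compound 4 rests on one precedent only. For compound 4 the step of a 40-fold lower number from compound 1 to compound 4 (1.60 log units; beyond the scatter) is expected, somewhat smaller than the measured step because a 52-fold lower number from compound 2 to compound 3 (1.71 log units; beyond the scatter) was observed on a different core and a single example gives no measure of how far the effect carries. Compound 4 is estimated at 900 nM in this assay, with a range from 200 nM to 5000 nM.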

Compound 4, concentration for 50% growth inhibition: 4.9 nM
For compound 4 the middle estimate is 180-fold (2.26 log units) above the measured one; measured number outside the range, below it.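

In this assay, replacing methylsulfanyl with the selenium-bearing group, on a carbon with a double bond to nitrogen, gives a 7300-fold lower number from compound 1 to compound 4 (3.86 log units; beyond the scatter), so the direction of the earlier step carries over to the core of compound 1. The direction is shared by both cores, but the size of the step does not transfer from one to the other: the same change on two cores in this assay, a 52-fold lower number (1.71 log units; beyond the scatter) from compound 2 to compound 3 and a 7300-fold lower number (3.86 log units; beyond the scatter) from compound 1 to compound 4, 140-fold (2.15 log units) apart, beyond the scatter of two such steps

Among these compounds, with only two cores, this shows that the size of the step depends on the core, but it gives no rule for predicting that size on a further core and no explanation for the gap, and the result rests on growth inhibition in a single cell line.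

The compounds shown leave open whether the step survives when a longer chain, such as ethyl or benzyl, stands on the selenium in place of its methyl group, and what an amine on the same carbon would give. Also open, going by these compounds, is whether a third core would yield a step closer to the smaller or the larger of the two, which would show how much weight either can carry as a precedent.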